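Aryl amine variation on the shared core: compound 4

The compounds below may be only part of what the source reports. "The series", "measured", "known", "first", "only" and "open" are said of these compounds alone.

Measured compounds:
compound 1 `COc1ccc(Nc2ncc(C(F)(F)F)c(N3Cc4cccc(N(C)S(C)(=O)=O)c4C3)n2)cc1C(F)(F)F` gives 14000 nM in a functional assay on HeLa cells (Homo sapiens) for antiproliferative activity, read by spectrophotometry, with a stated time of 2 days; a higher number here means a weaker inhibitor of growth, a lower number a stronger inhibitor of growth.
compound 2 `CN(c1cccc2c1CN(c1nc(Nc3ccc(C(F)(F)F)cc3)ncc1C(F)(F)F)C2)S(C)(=O)=O` reaches only the limit > 30000 nM in this assay; it is a limit, not a number.
compound 3 `COc1cc(Nc2ncc(C(F)(F)F)c(N3Cc4cccc(N(C)S(C)(=O)=O)c4C3)n2)cc(OC)c1` gives 7000 nM in this assay.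

Compound 3 holds the lowest of the two numbers in this assay. Its nearest neighbour is compound 1, with a 2.0-fold lower number from compound 1 to compound 3 (0.30 log units; within the scatter), which sits within the scatter, so the two cannot be ordered. The step of an at least 4.2-fold lower number from compound 2 to compound 3 (0.63 log units; beyond the scatter) is beyond the scatter, though one end of it rests on a limit (the limit of > 30000 nM in this assay, at which 1 of the 3 values shown sits). The step of an at least 2.1-fold higher number from compound 1 to compound 2 (0.33 log units; beyond the scatter) likewise rests on that limit.

Compound 4 `Cc1cc(C)cc(Nc2ncc(C(F)(F)F)c(N3Cc4cccc(N(C)S(C)(=O)=O)c4C3)n2)c1` differs from compound 3 in one place: 3,5-dimethylphenyl in place of 3,5-dimethoxyphenyl on a nitrogen on an aromatic ring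

Among the compounds with values here, none of the measured steps makes this kind of change; each of them swaps the whole aryl group for another with a different substitution pattern, and the two numbers that exist (compound 1 and compound 3) lie within the scatter of each other. There is therefore no measured basis for a large step in either direction. The expectation is a small step, a 1.4-fold higher number from compound 3 to compound 4 (0.15 log units; within the scatter), not clearly beyond the scatter. Compound 4 is estimated at 10000 nM, with a range from 4000 nM to 30000 nM.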

Compound 4, concentration for 50% growth inhibition: > 30000 nM
Compound 4: a limit, no number; the forecaster's own chance of this, stated with the estimate: 20%; middle value at least 3.0-fold (0.47 log units) from the limit.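

In this assay compound 4 gives > 30000 nM, which is a limit and not a number. Within the data shown here, with the substitution pattern on the phenyl ring held fixed and only the groups exchanged, the change on the nitrogen gives an at least 4.2-fold higher number from compound 3 to compound 4 (0.63 log units; beyond the scatter), so at this position the 3,5-pattern alone does not keep a measurable number, something the earlier steps could not show since each of them altered the pattern as well; the comparison with the other aryl group that has a number gives an at least 2.1-fold higher number from compound 1 to compound 4 (0.33 log units; beyond the scatter). The step between compound 2 and compound 4 cannot be read, and the upper end of the assay now limits what this series can show: the limit of > 30000 nM in this assay, at which 2 of the 4 values shown sit.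

Among these compounds, only one pair, compound 3 and compound 4, isolates the exchange of methoxy for methyl, so a single comparison carries this reading and it says nothing yet about other groups on the same ring. Open, on these data alone, is how a 3,5-dichlorophenyl, a 3,5-dihydroxyphenyl or a phenyl bearing a single methoxy group would read on this nitrogen, and whether any of them would separate from compound 3 by more than the scatter.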